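This account rests on a few compounds, and the source may have more. Where it says the series, first, only, none or still open, it means among the compounds named here.

Compounds measured so far in a functional assay on KB cells (Homo sapiens) for cytotoxicity; on this read-out lower numbers stand for an effect already at smaller amounts and higher numbers for an effect only at larger amounts of compound:
- compound 1 `Cn1ccnc1/C=N/Nc1ccnc2cc(Cl)ccc12` gives 17.1 uM
- compound 2 `Cn1cncc1/C=N/Nc1ccnc2cc(Cl)ccc12` gives 73.8 uM
- compound 3 `Oc1cc(/C=N/Nc2ccnc3cc(Cl)ccc23)ccc1CN1CCCC1` gives 152 uM

Compound 2 holds the middle place among these three numbers. Its number is higher than that of compound 1 and lower than that of compound 3, and both gaps lie beyond the usual scatter.

The next compound, compound 4 `Clc1ccc2c(N/N=C/c3cccs3)ccnc2c1`, has not yet been measured. It carries thiophen-2-yl in place of 1-methyl-1H-imidazol-5-yl on a carbon with a double bond to nitrogen.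

Within the data shown here, one measured step bears on this place. Putting 1-methyl-1H-imidazol-5-yl in place of 1-methyl-1H-imidazol-2-yl gave a 4.3-fold higher number from compound 1 to compound 2 (0.64 log units; beyond the scatter) and so a modest change beyond the scatter. Among the measured compounds shown here, no single-place step connects compound 3 to the others, and no measured compound carries thiophen-2-yl, so the direction remains uncertain. Compound 1 at 17.1 uM shows that a five-membered aromatic ring at this place can give a lower number, so a modest move that way is expected. The estimated change in this assay is a 2.5-fold lower number from compound 2 to compound 4 (0.39 log units; beyond the scatter). The estimated value for compound 4 is 30 uM with an expected range (8 uM to 110 uM).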

Compound 4, concentration for half-maximal effect: 10.4 uM
Estimate against measurement, compound 4: 2.9-fold (0.46 log units) above, within the range that was stated.
By their numbers in this assay, from the lowest: compounds 4 and 1 (each within the scatter of the next); then compound 2; then compound 3.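

In this assay, thiophen-2-yl in place of 1-methyl-1H-imidazol-5-yl on a carbon with a double bond to nitrogen gives a 7.1-fold lower number from compound 2 to compound 4 (0.85 log units; beyond the scatter), so a ring with sulfur and no nitrogen is accepted here and a low number does not depend on an imidazole ring. Set against the other imidazole group, the same ring gives a 1.6-fold lower number from compound 1 to compound 4 (0.22 log units; within the scatter), which leaves compound 1 and compound 4 level and makes compound 2 the one that stands apart among these three five-membered aromatic rings. Nothing available explains why the 1-methyl-1H-imidazol-5-yl compound differs from the other two, so the reason for this pattern remains unknown.

The compounds shown leave open whether furan-2-yl, thiophen-3-yl or a six-membered ring such as pyridin-2-yl would stay level with compound 1 and compound 4 at this place, or would move the number as the shift between the two imidazole groups did. Among these compounds, they also leave open how compound 3 relates to the others, since no single-place step ties it to them.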